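Compound 2 to compound 4: replacing the carbamoyl group

This account rests on a few compounds, and the source may have more. Where it says the series, first, only, none or still open, it means among the compounds named here.

Measured in an ADME assay on Vero cells (Chlorocebus sabaeus) for cytotoxicity, read by MTT assay, with a stated time of 96 h; on this read-out higher numbers stand for lower toxicity in this test and lower numbers for higher toxicity in this test:
- compound 1 `C/C(=N\NC(N)=S)c1ccc2[nH]c(-c3ccc(Cl)cc3)nc2c1`: > 100000 nM (a limit)
- compound 2 `C/C(=N\NC(N)=O)c1ccc2c(c1)nc(-c1ccc(Cl)cc1)n2C1CCCCC1`: > 100000 nM (a limit)
- compound 3 `C/C(=N\NC(N)=O)c1ccc2c(c1)nc(-c1ccoc1)n2C1CCCCC1`: "not determined" (no result reported)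

Compound 2 gives only a limit, > 100000 nM. This is the limit of > 100000 nM in this assay, at which 2 of the 3 values shown sit.

Compound 4 `C/C(=N\NC(N)=S)c1ccc2c(c1)nc(-c1ccc(Cl)cc1)n2C1CCCCC1` loses the carbamoyl group of compound 2, and a new group enters on the same amine nitrogen: a group of 3 heavy atoms (1 carbon, 1 nitrogen, 1 sulfur; no ring) in place of a group of 3 heavy atoms (1 carbon, 1 nitrogen, 1 oxygen; no ring), on an amine nitrogen.

Going by the values given here, no single-place step has been measured in this assay. Compound 1 carries the entering group, and its result is also a limit, > 100000 nM. On that basis, no change beyond the scatter is expected, in either direction. The expected step runs an at least 1.1-fold lower number from compound 2 to compound 4 (0.04 log units; that floor lies within the scatter). Compound 4 is estimated at 90000 nM, within an expected range of 30000 nM to 200000 nM.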

Compound 4, half-maximal cytotoxic concentration: > 100000 nM
Compound 4 gave a limit, no number (the forecaster's own chance of this, stated with the estimate: 60%); middle value at least 1.1-fold (0.04 log units) away from the limit.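

In this assay compound 4 gives > 100000 nM, a limit, so its steps from compound 2 and from compound 1 cannot be read: the limit of > 100000 nM in this assay, at which 3 of the 4 values shown sit.

The compounds shown leave open whether the sulfur-bearing group in place of carbamoyl, or cyclohexyl in place of hydrogen, changes this read-out at all.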